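The source may report more compounds than this note shows. Statements on the series, on what has been measured and on what is new or still open speak of the compounds shown alone.

Measured so far in an ADME assay on L929 cells (Mus musculus) for cytotoxicity, read by resazurin assay, with a stated time of 48 h; a higher number here means that more compound is tolerated, a lower number that less compound is tolerated:
compound 1 `N#CCn1c2ccc([N+](=O)[O-])cc2c(=O)n1Cc1ccccc1` — > 256000 nM
compound 2 `COC(=O)CCn1c2ccc([N+](=O)[O-])cc2c(=O)n1Cc1ccccc1` — > 256000 nM

In this assay compound 1 gives > 256000 nM, which is a limit of the assay and not a number. Compound 2 likewise gives only a limit, > 256000 nM. For the measured compounds named here, the one measured step, a step that the two limits leave unreadable from compound 1 to compound 2, is therefore unreadable, as both of its ends sit at the limit of > 256000 nM in this assay, at which 2 of the 2 values shown sit. Compound 1 thus stands only at a limit on the numbers shown, and the one further value shown is a limit as well.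

Compound 3 `O=c1c2cc([N+](=O)[O-])ccc2n(CCO)n1Cc1ccccc1` differs from compound 1 by hydroxymethyl in place of cyano on a saturated chain carbon bound to an aromatic nitrogen. The measured step bears on this change only in that it also replaces the cyano on the same saturated chain carbon bound to an aromatic nitrogen, and it shows no readable size. No step beyond the scatter is expected from compound 1 to compound 3 in this assay; the expected step is a step that the limit leaves unreadable from compound 1 to compound 3. Compound 3 is expected to give 300000 nM, with a range from 150000 nM to 1000000 nM, most likely again reported only as a limit.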

Compound 3, concentration lethal to 50% of the cells: > 256000 nM
Compound 3 gave a limit, no number; the forecaster's own chance of this, stated with the estimate: 80%; the middle value does not contradict the limit.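

Compound 3 adds no readable step to compound 1 or compound 2 in this assay, and all steps among these compounds remain unreadable: the limit of > 256000 nM in this assay, at which 3 of the 3 values shown sit. The compounds shown leave open what number any of them would give, and whether the chain groups differ at all in this assay.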